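The compounds below may be only part of what the source reports. "The series", "measured", "known", "first", "only" and "open" are said of these compounds alone.

Compound 1 `O=C(O)c1cccc(COc2ccc(OCCOCCNC3CCCC3)cc2)c1` is the starting point. In a functional assay on SK-OV-3 cells (Homo sapiens) for inhibition, read by CCK-8 assay, with a stated time of 70 h (on this read-out higher numbers stand for weaker inhibition and lower numbers for stronger inhibition), compound 1 gives only a limit of the assay, > 100000 nM. This puts compound 1 at the limit of > 100000 nM in this assay, at which 1 of the 3 values shown sits. Two related compounds do return numbers: compound 2 `c1ccc(COc2ccc(COc3ccc(OCCOCCNC4CCCCC4)cc3)cc2)cc1` gives 8080 nM in this assay, and compound 3 `COc1cc(OCCOCCNC2CCCC2)ccc1OCc1ccccc1` gives 44600 nM. Compound 4 `O=[N+]([O-])c1ccc(COc2ccc(OCCOCCNC3CCCC3)cc2)cc1` has not yet been tested. It differs from compound 1 in a single place: 4-nitrophenyl in place of 3-carboxyphenyl on a saturated chain carbon bound to an oxygen on an aromatic ring. For the measured compounds named here, no step between measured compounds sizes this change. Compound 4 is nevertheless expected to improve on compound 1, which sits only at the limit of > 100000 nM in this assay, at which 1 of the 3 values shown sits. The expected step from compound 1 to compound 4 is estimated as an at least 3.3-fold lower number from compound 1 to compound 4 (0.52 log units; beyond the scatter). Compound 4 is expected to reach about 30000 nM, with a likely range from 8000 nM to 120000 nM.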

Compound 4, half-maximal inhibitory concentration: 20300 nM
For compound 4 the middle estimate is 1.5-fold (0.17 log units) above the measured one; measured number inside the range.
By their numbers in this assay, from the lowest: compound 2; then compound 4; then compound 3. At a limit, above all of these: compound 1.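

For the compounds shown here, this is the first readable step at this place, on a saturated chain carbon bound to an oxygen on an aromatic ring. In this assay, 4-nitrophenyl in place of 3-carboxyphenyl gives an at least 4.9-fold lower number from compound 1 to compound 4 (0.69 log units; beyond the scatter), so the group here can carry the shared core from a limit to a measured number. The true size of the step stays unknown because compound 1 has only a limit: the limit of > 100000 nM in this assay, at which 1 of the 4 values shown sits.

Still open, from the compounds shown here alone, is whether the gain comes from losing the carboxylic acid or from gaining the nitro group. Going by these compounds, how a plain phenyl, an aniline amine or a nitrile at this place would compare also remains open.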